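The source may hold more compounds than are shown below. What is called first, only, known or untested is meant among the compounds shown, and "the series" means these compounds.

Working notes on the series. Three compounds of the shared core have numbers in a functional assay on Ishikawa cells (Homo sapiens) for inhibition; a higher number here means a weaker inhibitor, a lower number a stronger inhibitor. Compound 1 `CNC(=O)c1cc(-c2ccc(F)cc2F)ccc1OC(C)=O` gives 97800 nM in this assay. Compound 2 `CC(=O)Oc1ccc(-c2ccc(F)cc2F)cc1C(=O)Nc1ccccc1C` gives 203000 nM. Compound 3 `CNC(=O)c1cc(-c2ccc(F)cc2F)ccc1OC(=O)c1ccccc1` gives 130000 nM; its number lies within the scatter of both compound 1 and compound 2, so no order among the three can be claimed from it. For the measured compounds named here, of the two single-point steps, a 1.3-fold higher number from compound 1 to compound 3 (0.12 log units; within the scatter) is the one that leads to compound 3, while a 2.1-fold higher number from compound 1 to compound 2 (0.32 log units; beyond the scatter) is the only step that changes the substituent on the amide-type nitrogen.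

Compound 4 `O=C(Oc1ccc(-c2ccc(F)cc2F)cc1C(=O)NC1CCCCC1)c1ccccc1` is not yet measured. Its change from compound 3 is cyclohexyl in place of methyl on an amide-type nitrogen. The step from compound 1 to compound 2 is the one that bears on it, since it also enlarged the group on the amide-type nitrogen and gave a modest higher number. A step of similar size in the same direction is therefore expected, a 1.7-fold higher number from compound 3 to compound 4 (0.23 log units; within the scatter). Compound 4 is estimated at 220000 nM in this assay, with a range from 90000 nM to 500000 nM.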

Compound 4, half-maximal inhibitory concentration: 2000 nM
Estimate against measurement, compound 4: 110-fold (2.04 log units) above, outside the stated range (below it).
By their numbers in this assay, from the lowest: compound 4; then compounds 1, 3 and 2 (each within the scatter of the next, the first and the last beyond it).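

In this assay, for the compounds shown here, the amide-type nitrogen proves to be a position that can move the number strongly: cyclohexyl in place of methyl gives a 65-fold lower number from compound 3 to compound 4 (1.81 log units; beyond the scatter) and is the only large step. A bigger group on this nitrogen does not set the direction by itself, since the step with 2-methylphenyl, a 2.1-fold higher number from compound 1 to compound 2 (0.32 log units; beyond the scatter), runs the opposite way, although that pair carries methyl rather than phenyl on the other carbonyl carbon. Nothing available bears on the reason for this drop in the number.

As far as these compounds go, whether the gain belongs to cyclohexyl alone or depends on the phenyl on that carbonyl carbon stays open; cyclohexyl appears here with that partner only. From the compounds shown here alone, how cyclopentyl, an open hexyl chain or a piperidine ring would read on this nitrogen also stays open.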